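Dimethyl Urea Variant of a Tetrahydronaphthalene Sulfone Series

The source may report more compounds than this note shows. Statements on the series, on what has been measured and on what is new or still open speak of the compounds shown alone.

Measured compounds:
- compound 1, `O=S(=O)(c1cccc(F)c1)c1ccc2c(c1)CCC[C@H]2CN1CC(O)C1`: 0.1 nM
- compound 2, `NC(=O)CNC[C@@H]1CCCc2cc(S(=O)(=O)c3cccc(F)c3)ccc21`: 0.1 nM
- compound 3, `NC(=O)NC[C@@H]1CCCc2cc(S(=O)(=O)c3cccc(F)c3)ccc21`: 0.2 nM

In an assay on isolated protein for displacement of a labelled ligand from 5-hydroxytryptamine receptor 6 (Homo sapiens) (on this read-out higher numbers stand for weaker inhibition and lower numbers for stronger inhibition), the three numbers sit close together. Compound 3 differs from each of the other two only within the scatter: a 2.0-fold higher number from compound 1 to compound 3 (0.30 log units; within the scatter) and a 2.0-fold higher number from compound 2 to compound 3 (0.30 log units; within the scatter), while no change at the digits printed from compound 1 to compound 2 (within the scatter). Three rather different polar groups on the chain carbon bound to the shared core thus give the same outcome, which suggests the region tolerates change, although compound 4 lies outside what has been tested.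

Compound 4, `CN(C)C(=O)NC[C@@H]1CCCc2cc(S(=O)(=O)c3cccc(F)c3)ccc21`, carries dimethylamino in place of amino on a carbonyl carbon. For the measured compounds named here, no measured step shows the loss of a hydrogen-bond donor, so the expectation rests on the general flatness seen in a 2.0-fold higher number from compound 1 to compound 3 (0.30 log units; within the scatter) and a 2.0-fold higher number from compound 2 to compound 3 (0.30 log units; within the scatter). A small weakening at most is expected, likely within the scatter. Compound 4 is expected to give 0.3 nM in this assay, with a range from 0.1 nM to 1.2 nM. This amounts to an expected step of a 1.5-fold higher number from compound 3 to compound 4 (0.18 log units; within the scatter).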

Compound 4, inhibition constant: 2.51 nM
Compound 4: middle estimate off by 8.4-fold (0.92 log units), on the low side, and the stated range ends below it.
By their numbers in this assay, from the lowest: compounds 1, 2 and 3 (each within the scatter of the next); then compound 4.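

In this assay, the flat picture set by the first three compounds ends with this change: dimethylamino in place of amino on a carbonyl carbon gives (a 13-fold higher number from compound 3 to compound 4 (1.10 log units; beyond the scatter)), so this position is not tolerant of every group placed there. The step is no smaller when read against the other two groups on the chain carbon, at (a 25-fold higher number from compound 2 to compound 4 (1.40 log units; beyond the scatter)) and (a 25-fold higher number from compound 1 to compound 4 (1.40 log units; beyond the scatter)), which leaves compound 4 alone beyond the scatter of the other compounds. Nothing available explains why this change costs so much.

The change swaps amino, with 1 heavy atom and 1 hydrogen-bond donor, for dimethylamino, with 3 heavy atoms and 0 hydrogen-bond donors, and the compounds shown cannot separate these two differences. As far as these compounds go, whether methylamino on the same carbonyl carbon keeps the numbers of compound 3 or follows compound 4 stays open, as does the outcome for a ring such as azetidin-1-yl there.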